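A few compounds are considered here, and "the series" means these few. Any claim that something is new, unique, unknown or untested is made for them only; others in the source may bear on it.

Measured compounds in a physicochemical assay for solubility, in phosphate buffer, with a stated time of 18 h; a higher number here means a more soluble compound, a lower number a less soluble compound:
compound 1 `N#Cc1c(N)nc2nc(Cc3ccccc3)ncc2c1N` gives 13000 nM
compound 2 `CC(C)(C)c1ncc2c(N)c(C#N)c(N)nc2n1` gives 37200 nM

Compound 2 stands highest of the two numbers; the nearest is compound 1, and the step of a 2.9-fold higher number from compound 1 to compound 2 (0.46 log units; beyond the scatter) puts it beyond the scatter. Compound 3 `CC(C)(C)c1nc(C2CCCC2)c2c(N)c(C#N)c(N)nc2n1` has not yet been measured. It differs from compound 2 by cyclopentyl in place of hydrogen on an aromatic carbon. Going by the values given here, no measured step covers such a change: the only step known, from benzyl to tert-butyl, is of another kind and bears on it only loosely. The expectation for compound 3 is a modest decrease, a 3.1-fold lower number from compound 2 to compound 3 (0.49 log units; beyond the scatter), giving an estimated value of 12000 nM, within a range from 4000 nM to 35000 nM.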

Compound 3, solubility: < 1000 nM
Compound 3: a limit, no number; the forecaster's own chance of this, stated with the estimate: 5%; at least 12-fold (1.07 log units) between middle value and limit.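

The earlier compounds shown here changed only benzyl to tert-butyl and left this aromatic carbon, next to the ring nitrogen, carrying hydrogen. In this assay, cyclopentyl in place of that hydrogen gives an at least 37-fold lower number from compound 2 to compound 3 (1.57 log units; beyond the scatter), so this position is far from indifferent to the change. Compound 3 carries a limit and not a number, so the true size of the step stays unknown: the limit of < 1000 nM in this assay, at which 1 of the 3 values shown sits.

Going by these compounds, it remains open whether methyl, an amine or a carboxylic acid on this carbon would stay closer to compound 2. Also open, on these data alone, is whether cyclopentyl here would act alike alongside benzyl, as in compound 1.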